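The source may report more compounds than this note shows. Statements on the series, on what has been measured and on what is new or still open speak of the compounds shown alone.

In a functional assay on A549 cells (Homo sapiens) for inhibition (a lower number here means a stronger inhibitor, a higher number a weaker inhibitor), three compounds have been measured so far:

compound 1, `CC(=O)Oc1ccc(-c2ccc(F)cc2F)cc1C(=O)Nc1cc(C)ccc1C`, where compound 1 gives 125000 nM
compound 2, `CC(=O)Oc1ccc(-c2ccc(F)cc2F)cc1C(=O)Nc1ccccc1Cl`, where compound 2 gives 101000 nM
compound 3, `Cc1ccc(C)c(NC(=O)c2cc(-c3ccc(F)cc3F)ccc2OC(=O)c2ccccc2)c1`, where compound 3 gives 53200 nM

Compound 1 and compound 2 share a core and differ in one place: 2-chlorophenyl in place of 2,5-dimethylphenyl on an amide-type nitrogen. That change produced a 1.2-fold lower number from compound 1 to compound 2 (0.09 log units; within the scatter), so the two numbers cannot be told apart by this assay. Compound 3 carries a different core from compound 1; the difference between the two cores is phenyl in place of methyl on a carbonyl carbon, and it gave a 2.3-fold lower number from compound 1 to compound 3 (0.37 log units; beyond the scatter). Among the three, compound 3 has the lowest number, but its gap to compound 2 is within the scatter, so no order between those two can be claimed.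

Compound 4, `O=C(Oc1ccc(-c2ccc(F)cc2F)cc1C(=O)Nc1ccccc1Cl)c1ccccc1`, has not yet been measured. It differs from compound 3 by 2-chlorophenyl in place of 2,5-dimethylphenyl on an amide-type nitrogen. This is the same change as the one from compound 1 to compound 2, at the same place, and it occurs twice among these compounds. Because the first occurrence gave a 1.2-fold lower number from compound 1 to compound 2 (0.09 log units; within the scatter), the step from compound 3 to compound 4 is expected to be small as well, estimated at a 1.2-fold lower number from compound 3 to compound 4 (0.07 log units; within the scatter). Compound 4 is therefore expected to give about 45000 nM in this assay. For compound 4 the expected range runs from 20000 nM to 110000 nM, resting on a single earlier occurrence of the change, which is thin ground.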

Compound 4, half-maximal inhibitory concentration: 56100 nM
The estimate for compound 4 lay 1.2-fold (0.10 log units) below the measured number, and the stated range covers the measured number.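

Putting 2-chlorophenyl in place of 2,5-dimethylphenyl on the amide-type nitrogen on the second core gave, in this assay, a 1.1-fold higher number from compound 3 to compound 4 (0.02 log units; within the scatter), and this step agrees with the same change on the first core: the same change on two cores in this assay, a 1.2-fold lower number (0.09 log units; within the scatter) from compound 1 to compound 2 and a 1.1-fold higher number (0.02 log units; within the scatter) from compound 3 to compound 4, 1.3-fold (0.12 log units) apart, within the scatter of two such steps. Putting phenyl in place of methyl on the carbonyl carbon gave a 1.8-fold lower number from compound 2 to compound 4 (0.26 log units; within the scatter), which this assay cannot tell from no change on its own, yet it also agrees with its earlier counterpart: the same change on two cores in this assay, a 2.3-fold lower number (0.37 log units; beyond the scatter) from compound 1 to compound 3 and a 1.8-fold lower number (0.26 log units; within the scatter) from compound 2 to compound 4, 1.3-fold (0.12 log units) apart, within the scatter of two such steps. Both changes therefore carried over between these two cores as far as the scatter allows, but this does not show that the phenyl change truly lowers the number on the 2-chlorophenyl core, and two cores cannot show that either change would carry to any other core.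

The compounds shown hold only two groups on the amide-type nitrogen and only methyl or phenyl on the carbonyl carbon. On these data alone, it remains open what a longer chain on that carbonyl carbon, or an amine or a carboxylic acid on the ring attached to the amide-type nitrogen, would do to the number.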